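Pyridyl for chlorophenyl: a step from compound 2

A few compounds are considered here, and "the series" means these few. Any claim that something is new, unique, unknown or untested is made for them only; others in the source may bear on it.

Three compounds carry numbers in an in vitro functional assay on HEK285-7 cells for antagonist activity at prostaglandin D2 receptor 2 (Homo sapiens), read by BRET and beta-arrestin recruitment; on this read-out higher numbers stand for weaker inhibition and lower numbers for stronger inhibition. Compound 1 `O=C(O)Cc1sc(C2COc3ccccc3O2)nc1-c1ccc(Cl)cc1` gives 2000 nM, compound 2 `O=C(O)Cc1sc(C(c2ccc(F)cc2)c2ccc(F)cc2)nc1-c1ccc(Cl)cc1` gives 180 nM, and compound 3 `O=C(O)Cc1sc(C(c2ccccc2)c2ccccc2)nc1-c1ccc(F)c(F)c1` gives 43 nM. Compound 2 stands second highest of the three, with compound 3 lower by more than the scatter and compound 1 higher by more than the scatter. The measured compounds differ in more than one place, so no single-change step can be read from them.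

Compound 4 `O=C(O)Cc1sc(C(c2ccc(F)cc2)c2ccc(F)cc2)nc1-c1cc(F)nc(F)c1` differs from compound 2 in one place: 2,6-difluoropyridin-4-yl in place of 4-chlorophenyl on an aromatic carbon. Nothing measured isolates this change. Compound 4 is expected to give 300 nM in this assay, within 80 nM to 1200 nM. The expected step of a 1.7-fold higher number from compound 2 to compound 4 (0.22 log units; within the scatter) is small, toward a higher number, and may not exceed the scatter.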

Compound 4, half-maximal inhibitory concentration: 110 nM
For compound 4 the middle estimate is 2.7-fold (0.44 log units) above the measured one; the measured number falls inside the stated range.
By their numbers in this assay, from the lowest: compound 3; then compounds 4 and 2 (each within the scatter of the next); then compound 1.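

In this assay, among the compounds shown here, the change to 2,6-difluoropyridin-4-yl in place of 4-chlorophenyl gives a 1.6-fold lower number from compound 2 to compound 4 (0.21 log units; within the scatter) and is the first single-change step. At this aromatic carbon next to the ring nitrogen, a six-membered aromatic ring with 1 hetero atom and 1 hydrogen-bond acceptor therefore reads within the scatter of a carbon-only ring with neither. No evidence is available on why the two groups read alike.

Going by these compounds, whether the ring nitrogen or the two fluorines matter more stays open. A plain pyridyl group or a difluorophenyl group would separate the two.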